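The source may report more compounds than this note shows. Statements on the series, on what has been measured and on what is new or still open speak of the compounds shown alone.

Measured so far in an assay on isolated protein for displacement of a labelled ligand from metabotropic glutamate receptor 5 (Homo sapiens), with a stated time of 60 min, tested at 1 uM; a higher number here means more inhibition at the concentration tested (going by the name of the read-out), a lower number less inhibition:
compound 1 `COc1ccc(S(=O)(=O)c2cnc3ccc(F)cc3c2N2CCC(C)CC2)cc1` gives 85%
compound 2 `CC1CCN(c2c(S(=O)(=O)c3ccc(Cl)cc3)cnc3ccc(F)cc23)CC1` gives 80%
compound 3 `COc1ccc(S(=O)(=O)c2cnc3ccc(F)cc3c2N2CCC(C)CC2)cc1Cl` gives 82%

Compound 2 has the lowest of the three numbers, but the gaps are small: a number 5 percentage points lower from compound 1 to compound 2 (within the scatter) and a number 2 percentage points higher from compound 2 to compound 3 (within the scatter) are both inside the usual scatter, as is a number 3 percentage points lower from compound 1 to compound 3 (within the scatter). The three compounds therefore cannot be told apart on these data; all of the changes made so far, chloro in place of methoxy, chloro in place of hydrogen, 3-chloro-4-methoxyphenyl in place of 4-chlorophenyl on the sulfonyl sulfur, left the read-out essentially unmoved.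

Compound 4 `CC1CCN(c2c(S(=O)(=O)c3ccc(Cl)cc3)cnc3ccc(Cl)cc23)CC1` is the next point in the series. Relative to compound 2 it has chloro in place of fluoro on an aromatic carbon. For the measured compounds named here, none of the measured steps touches this part of the core; every step so far was made on the aromatic ring attached to the sulfonyl sulfur, so no step bears directly on this change. Going by the values given here, the only guidance is that halogen swaps elsewhere gave steps within scatter, and the same is expected here: no step beyond scatter, with compound 2 as the anchor. Compound 4 is estimated at 80% in this assay, with a range of 65% to 92%. The implied change, no change at the digits printed from compound 2 to compound 4 (within the scatter), is expected to sit within the scatter.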

Compound 4, a percentage reported as inhibition, at one concentration (the size of the read-out at that concentration, not a potency): 92%
Compound 4: middle estimate off by 12 percentage points, on the low side; the range from low to high includes it.
By their numbers in this assay, from the lowest: compounds 2, 3, 1 and 4 (each within the scatter of the next, the first and the last beyond it).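

In this assay, chloro in place of fluoro on an aromatic carbon of the shared core gives a number 12 percentage points higher from compound 2 to compound 4 (beyond the scatter), a modest step and the only one in the series that lies beyond the scatter. The earlier steps all fell on the aromatic ring attached to the sulfonyl sulfur and stayed within the scatter, so this carbon of the fused system is the one place shown where exchanging a single atom moves the read-out measurably, although the finding rests on one matched pair with the 4-chlorophenyl group on the sulfonyl sulfur held constant. Nothing available accounts for the step, and the read-out is a size at one concentration rather than a potency.

The compounds shown leave open whether the same exchange gives a similar step when the sulfonyl sulfur carries 4-methoxyphenyl or 3-chloro-4-methoxyphenyl instead. They also leave open how this carbon responds to other groups, such as bromo, methyl or nitrile, or to plain hydrogen, so no trend across substituents can yet be drawn from a single fluoro and chloro pair.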